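Replacing a sulfonamide ethyl group with a methyl(phenyl) group

This account rests on a few compounds, and the source may have more. Where it says the series, first, only, none or still open, it means among the compounds named here.

Measured compounds:
- compound 1, `CC1(C)C=C(n2ccccc2=O)c2cc(S(=O)(=O)N=[N+]=[N-])ccc2O1`: 77.2%
- compound 2, `CCNS(=O)(=O)c1ccc2c(c1)C(n1ccccc1=O)=CC(C)(C)O2`: 87%
- compound 3, `CC1(C)C=C(n2ccccc2=O)c2cc(S(=O)(=O)Nc3ccccc3)ccc2O1`: 7.85%; 88% (2 entries)

In a functional assay on the whole organism (trachea) with Rattus norvegicus as the target (on this read-out higher numbers stand for larger maximal responses and lower numbers for smaller maximal responses), compound 2 gives 87% and stands highest of the two single numbers, though its nearest neighbour, compound 1, lies within the scatter of it with 77.2%. Compound 4, `CN(c1ccccc1)S(=O)(=O)c1ccc2c(c1)C(n1ccccc1=O)=CC(C)(C)O2`, is not yet measured. It differs from compound 2 by methyl(phenyl)amino in place of ethylamino on a sulfonyl sulfur.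

Among the measured compounds shown here, only one step is measured here: a number 9.8 percentage points higher from compound 1 to compound 2 (within the scatter), a change on the same sulfonyl sulfur that left the response essentially unchanged. Compound 3 carries a phenylamino group on that sulfur and is the closest measured relative of compound 4, but its two entries disagree widely, (the several entries of compound 3 in this assay, 7.85%; 88% (2 entries)), so it gives no firm direction. On this basis the step of a number 5 percentage points lower from compound 2 to compound 4 (within the scatter) is expected to stay within the scatter, with a wide range to allow for the uncertainty seen in compound 3. Compound 4 is therefore estimated at 82% in this assay, between 45% and 95%.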

Compound 4, largest response reached (Emax), in percent of the reference or control that the assay uses: 86.5%
Estimate against measurement, compound 4: 4.5 percentage points below; measured number inside the range.
By their numbers in this assay, from the lowest: compounds 1, 4 and 2 (each within the scatter of the next).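

In this assay, the sulfonyl sulfur accepts a clearly larger group, and the response shows no change beyond the scatter (a number 0.5 percentage points lower from compound 2 to compound 4 (within the scatter)). This swap adds a six-membered aromatic ring and removes the hydrogen-bond donor of ethylamino, and the comparison with azido on the same sulfur also stays within the scatter (a number 9.3 percentage points higher from compound 1 to compound 4 (within the scatter)). Compound 1, compound 2 and compound 4 therefore show that these three quite different groups on this sulfur cannot be told apart in this read-out.

The step between compound 3 and compound 4, which would isolate the methyl group on the sulfonamide nitrogen, cannot be read because the entries for compound 3 disagree: the several entries of compound 3 in this assay, 7.85%; 88% (2 entries). As far as these compounds go, how a carboxylic acid or a morpholine on this sulfonyl sulfur would behave also remains open.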